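A few compounds are considered here, and "the series" means these few. Any claim that something is new, unique, unknown or untested is made for them only; others in the source may bear on it.

Compound 1 `COc1ccc(C(=O)Nc2nccn3cc(-c4ccccc4)nc23)cc1` gives 1%
Compound 2 `Cc1ccc(C(=O)Nc2nccn3cc(-c4ccccc4)nc23)cc1` gives 26%
Compound 3 `COc1ccc(C(=O)Nc2nc(-c3ccccc3)cn3cc(-c4ccccc4)nc23)cc1` gives 6%

In an assay on cells for displacement of a labelled ligand from adenosine receptor A1 (Homo sapiens), read by scintillation counting, with a stated time of 120 min, tested at 1 uM (on this read-out lower numbers stand for less inhibition and higher numbers for more inhibition at the one concentration tested (going by the name of the read-out)), compound 3 stands second highest of the three numbers. Its distance from compound 1 is small, as the step of a number 5 percentage points higher from compound 1 to compound 3 (within the scatter) shows, whereas compound 2 gives 26% and so stands clearly above compound 3.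

Compound 4 `Cc1ccc(C(=O)Nc2nc(-c3ccccc3)cn3cc(-c4ccccc4)nc23)cc1` differs from compound 3 only by methyl in place of methoxy on an aromatic carbon. This very change has been measured once before, between compound 1 and compound 2: a number 25 percentage points higher from compound 1 to compound 2 (beyond the scatter), a rise beyond the scatter. Because of a number 25 percentage points higher from compound 1 to compound 2 (beyond the scatter) a rise of similar size is expected here, namely a number 24 percentage points higher from compound 3 to compound 4 (beyond the scatter). Compound 4 is therefore estimated at 30%, with an expected range from 10% to 50%.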

Compound 4, a percentage reported as inhibition, at one concentration (the size of the read-out at that concentration, not a potency): 1%
Compound 4: the middle estimate sits 29 percentage points above what was measured; the whole stated range lies above it.
By their numbers in this assay, from the lowest: compounds 1, 4 and 3 (each within the scatter of the next); then compound 2.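

Methyl in place of methoxy has no single effect in this assay: with a number 5 percentage points lower from compound 3 to compound 4 (within the scatter), the rise seen on the core of compound 1 does not return on the core carrying the added phenyl. Read the other way, with a number 25 percentage points lower from compound 2 to compound 4 (beyond the scatter), adding phenyl lowers the number clearly only where methyl is present, so the two changes do not simply add up. Both comparisons say the same: the same change on two cores in this assay, a number 25 percentage points higher (beyond the scatter) from compound 1 to compound 2 and a number 5 percentage points lower (within the scatter) from compound 3 to compound 4, 30 percentage points apart, beyond the scatter of two such steps. A second reading gives the matching gap: the same change on two cores in this assay, a number 5 percentage points higher (within the scatter) from compound 1 to compound 3 and a number 25 percentage points lower (beyond the scatter) from compound 2 to compound 4, 30 percentage points apart, beyond the scatter of two such steps.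

As far as these compounds go, whether an amine or a carboxylic acid in this place would raise the number on either core remains open.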